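Hydrogen in place of 3,5-difluorophenyl: working notes

The source may report more compounds than this note shows. Statements on the series, on what has been measured and on what is new or still open speak of the compounds shown alone.

Measured in a functional assay on CFPAC-1 cells (Homo sapiens) for antiproliferative activity, read by MTT assay, with a stated time of 72 h; a lower number here means a stronger inhibitor, a higher number a weaker inhibitor:
- compound 1 `O=C1O[C@H]([C@@H](O)Cn2cc(-c3ccc(Br)cc3)nn2)C(OCc2ccccc2)=C1OCc1ccccc1`: 5830 nM
- compound 2 `O=C1O[C@H]([C@@H](O)Cn2cc(-c3cc(F)cc(F)c3)nn2)C(OCc2ccccc2)=C1OCc1ccccc1`: 62400 nM

Compound 2 holds the higher of the two numbers, so it is the weaker of the pair. Next is compound 3 `O=C1O[C@H]([C@@H](O)Cn2ccnn2)C(OCc2ccccc2)=C1OCc1ccccc1`, with the change hydrogen in place of 3,5-difluorophenyl on an aromatic carbon. Within the data shown here, the one measured step bearing on this is large and beyond the scatter: an 11-fold higher number from compound 1 to compound 2 (1.03 log units; beyond the scatter). It exchanges one substituted phenyl for another on the same aromatic carbon, so this assay clearly responds to that substituent. Among the measured compounds shown here, no measured compound lacks the substituent, however, so its removal remains poorly defined. A moderate move toward a lower number is expected, as compound 2 at 62400 nM already lies at the weak end. The expected step is a 2.1-fold lower number from compound 2 to compound 3 (0.32 log units; beyond the scatter). For compound 3 the estimated value is 30000 nM, with an expected range of 8000 nM to 110000 nM.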

Compound 3, half-maximal inhibitory concentration: > 100000 nM
Compound 3: only a limit was reported; the forecaster's own chance of this, stated with the estimate: 20%; middle value at least 3.3-fold (0.52 log units) from the limit.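

In this assay, compound 3 gives only a limit and not a number: the limit of > 100000 nM in this assay, at which 1 of the 3 values shown sits. Hydrogen in place of 4-bromophenyl gives an at least 17-fold higher number from compound 1 to compound 3 (1.23 log units; beyond the scatter), the first evidence that removing the aryl substituent from this aromatic carbon, and not only exchanging one substituted phenyl for another, changes the read-out well beyond the scatter. Hydrogen in place of 3,5-difluorophenyl gives an at least 1.6-fold higher number from compound 2 to compound 3 (0.20 log units; that floor lies within the scatter), a floor within the scatter, so this change cannot yet be shown to differ from no change at all.

Going by these compounds, what an unsubstituted phenyl, a 4-chlorophenyl or a simple methyl group would give on this aromatic carbon remains open. On these data alone, it is also open whether the bromine itself or the phenyl ring carrying it accounts for the lower number of compound 1.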